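Ethynyl in place of thiophen-2-yl on a limit-bound series

The source may hold more compounds than are shown below. What is called first, only, known or untested is meant among the compounds shown, and "the series" means these compounds.

In a functional assay on HepG2 cells (Homo sapiens) for antiproliferative activity, read by XTT assay, with a stated time of 72 h (a higher number here means a weaker inhibitor, a lower number a stronger inhibitor), compound 1 `CSc1ncnc2c1c(-c1ccoc1)cn2[C@@H]1O[C@H](CO)[C@@H](O)[C@H]1O` gives > 15000 nM, which is a limit and not a number. Compound 2 `CSc1ncnc2c1c(-c1cccs1)cn2[C@@H]1O[C@H](CO)[C@@H](O)[C@H]1O` gives > 20000 nM, again a limit. Compound 3 `CNc1ncnc2c1c(-c1cccs1)cn2[C@@H]1O[C@H](CO)[C@@H](O)[C@H]1O` also gives only a limit, > 20000 nM, so its place on the scale is not fixed by a number. Going by the values given here, no value is a true number so far: the data hold only the limit of > 15000 nM in this assay, at which 1 of the 3 values shown sits, and (the limit of > 20000 nM in this assay, at which 2 of the 3 values shown sit).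

The next structure is compound 4 `C#Cc1cn([C@@H]2O[C@H](CO)[C@@H](O)[C@H]2O)c2ncnc(NC)c12`, with ethynyl in place of thiophen-2-yl on an aromatic carbon.

Among the compounds with values here, two measured steps bear on this. The nearer one is a step that the two limits leave unreadable from compound 1 to compound 2, which brings in thiophen-2-yl, the group that leaves here. The other is a step that the two limits leave unreadable from compound 2 to compound 3, which gives methylamino, the group that compound 4 keeps. Neither has a readable size, so neither sets the size of the change in this assay. The expectation is therefore a stay near the limit, with no step beyond the scatter and a modest move toward stronger inhibition left open.

The expected change is an at least 1.3-fold lower number from compound 3 to compound 4 (0.12 log units; that floor lies within the scatter). For compound 4 the estimate is 15000 nM, with an expected range from 2500 nM to 30000 nM, and a further limit in place of a number is the likeliest report.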

Compound 4, half-maximal inhibitory concentration: > 15000 nM
Compound 4: a limit, no number (the forecaster's own chance of this, stated with the estimate: 65%); the middle value sits exactly at the limit.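

In this assay compound 3 gives > 20000 nM, a limit. Compound 4 gives > 15000 nM, also a limit, so no step can be read between compound 3 and compound 4. The compounds shown leave open what size of change, if any, ethynyl in place of thiophen-2-yl brings, and whether any group on the shared core gives a true number in this assay.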